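Swapping the Amide Aryl Group of Compound 3

This account rests on a few compounds, and the source may have more. Where it says the series, first, only, none or still open, it means among the compounds named here.

Of the compounds shown here, three have so far been measured in an ADME assay on cells (Hepatocyte, Rattus norvegicus) for metabolic stability; on this read-out lower numbers stand for slow clearance and higher numbers for fast clearance. Compound 1 `Cc1ccc2[nH]c(C(=O)N[C@H]3CCN(S(=O)(=O)N(C)C)C[C@@H]3C(=O)NCCN(C)C)cc2c1` gives 10 uL/min in this assay. Compound 2 `Cc1csc(C(=O)N[C@H]2CN(S(=O)(=O)c3ccccc3)C[C@@H]2C(=O)N[C@H]2CCCNC2)n1` is reported only at a limit of this assay, < 1 uL/min. Compound 3 `O=C(N[C@H]1CN(S(=O)(=O)c2ccccc2)C[C@@H]1C(=O)N[C@H]1CCCNC1)c1cc(C2CC2)n[nH]1` likewise sits at a limit of this assay, < 1 uL/min. Within the data shown here, the one single-point step measured, a step that the two limits leave unreadable from compound 2 to compound 3, cannot be sized because of the limit of < 1 uL/min in this assay, at which 2 of the 3 values shown sit. Compound 3 therefore stands at the slow end of what has been shown, without a number of its own.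

Compound 4 `O=C(N[C@H]1CN(S(=O)(=O)c2ccccc2)C[C@@H]1C(=O)N[C@H]1CCCNC1)c1cc(-c2ccccc2)on1` differs from compound 3 in one place: 5-phenyl-1,2-oxazol-3-yl in place of 3-cyclopropyl-1H-pyrazol-5-yl on a carbonyl carbon. Among the measured compounds shown here, no measured step pairs a 5-phenyl-1,2-oxazol-3-yl group with anything else, and the one measured step is itself unreadable, so the expectation for compound 4 rests on the limit of compound 3 alone. Compound 4 is estimated to give 3 uL/min in this assay, within a range from 1 uL/min to 12 uL/min. The step expected is an at least 3.0-fold higher number from compound 3 to compound 4 (0.47 log units; beyond the scatter), a modest rise that may or may not exceed the scatter, with a real chance that this assay again reports only a limit.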

Compound 4, intrinsic clearance in a liver preparation (reported as CLH), per the amount of preparation that the assay uses: 6.8 uL/min
Compound 4: middle estimate off by 2.3-fold (0.36 log units), on the low side; the range from low to high includes it.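

Compound 4 gives the first reading above the limit among the compounds that differ only in the group on this carbonyl carbon, so in this assay this place does respond to a change of group. Placing 5-phenyl-1,2-oxazol-3-yl here in place of 3-cyclopropyl-1H-pyrazol-5-yl gives an at least 6.8-fold higher number from compound 3 to compound 4 (0.83 log units; beyond the scatter), and placing it here in place of 4-methyl-1,3-thiazol-2-yl gives an at least 6.8-fold higher number from compound 2 to compound 4 (0.83 log units; beyond the scatter). Neither step has a full size because each starts from a limit: the limit of < 1 uL/min in this assay, at which 2 of the 4 values shown sit.

As far as these compounds go, whether the rise goes with the phenyl ring or with the 1,2-oxazole ring stays open, and a 5-methyl-1,2-oxazol-3-yl group on this carbonyl carbon would separate the two. Also open, from the compounds shown here alone, is whether the same group would raise the number on the core of compound 1.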